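A few compounds are considered here, and "the series" means these few. Any claim that something is new, unique, unknown or untested is made for them only; others in the source may bear on it.

Two compounds share the same core, an acid-bearing side chain on a phenyl ether, and differ in the outer part of the molecule. Compound 1 `CC#CC(CC(=O)O)c1ccc(OCc2ccn3cc(-c4ccc(F)cc4)nc3c2)cc1` and compound 2 `CC#CC(CC(=O)O)c1ccc(OCc2ccc3nc(-c4ccc(CC)cc4)cn3c2)cc1` have each been tested. In an assay on isolated protein for agonist activity at Free fatty acid receptor 1 (Homo sapiens) (a higher number here means that more compound is needed for the effect, a lower number that less compound is needed), compound 1 gives 783 nM, and compound 2 gives 496 nM. Of these two numbers, that of compound 2 is the lower one, but its gap to compound 1 lies within the usual scatter of repeated measurements, so the two cannot be ranked against each other.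

Compound 3 `CC#CC(CC(=O)O)c1ccc(OCc2ccc3nc(-c4ccc(C)cc4)cn3c2)cc1` follows from compound 2 by a single change: hydrogen in place of methyl on a saturated chain carbon bound to an aromatic carbon. The 4-ethylphenyl group of compound 2 thus becomes a 4-methylphenyl group in compound 3, and nothing else moves.

Among the measured compounds shown here, no pair of measured compounds differing in one place is available to show what an edit of this kind does here. Since one carbon leaves from the chain on the outer ring, the step expected in this assay is a 1.3-fold higher number from compound 2 to compound 3 (0.10 log units; within the scatter), a small shift that is not expected to stand clearly beyond the scatter. Compound 3 is therefore estimated at 620 nM, with a range from 300 nM to 1300 nM.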

Compound 3, half-maximal effective concentration: 507 nM
Compound 3: the middle estimate sits 1.2-fold (0.09 log units) above what was measured; low and high end bracket the measured number.
By their numbers in this assay, from the lowest: compounds 2, 3 and 1 (each within the scatter of the next).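

Among the compounds shown here, this is the first pair that differs in one place, so the outer ring's substituent can now be read on its own. In this assay, replacing the 4-ethylphenyl group with the 4-methylphenyl group gives a 1.0-fold higher number from compound 2 to compound 3 (0.01 log units; within the scatter), so compound 2 and compound 3 cannot be told apart, and removing this one chain carbon has no readable effect on the number here. Nothing available explains this result at the level of the molecule.

For the compounds shown here, a single pair covers only the step from ethyl to methyl, so it sets no rule for other groups at this place on the outer ring, and compound 1 differs from compound 3 in more than one place and cannot fill that gap. Still open, going by these compounds, is whether a longer chain such as propyl, a branched group such as tert-butyl, an oxygen-linked group such as methoxy, or a plain hydrogen on the ring in place of the whole chain would also stay within the scatter or would move the number clearly in either direction.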